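The source may hold more compounds than are shown below. What is called first, only, known or untested is meant among the compounds shown, and "the series" means these compounds.

Compound 1 `C[C@H](NCCSCCC(N)C(=O)O)C(=O)O` was tested in an assay for inhibition of betaine--homocysteine S-methyltransferase 1 (Homo sapiens), tested at 20 uM (a lower number here means less inhibition, a higher number more inhibition at the concentration tested (going by the name of the read-out)), where compound 1 gives 19.8%. This is the lowest of the two numbers obtained so far. The other measured compound, compound 2 `NC(CC[Se]CCCCC(=O)O)C(=O)O`, gives 100% in this assay, a number higher by a margin well beyond the usual scatter of repeated measurements. Among the compounds with values here, no single-change step connects these two compounds, so their numbers simply stand side by side. Compound 3 `NC(CCSCCNCC(=O)O)C(=O)O` has not yet been measured; it differs from compound 1 by hydrogen in place of methyl on a saturated chain carbon bound to an amine nitrogen and a carbonyl carbon. Within the data shown here, with no single-change step available as a guide, the expected step is a number 8.2 percentage points higher from compound 1 to compound 3 (within the scatter), which is a modest change, possibly within the scatter or a small rise. In this assay compound 3 is therefore estimated at 28%, with a likely range from 5% to 65%.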

Compound 3, a percentage reported as inhibition, at one concentration (the size of the read-out at that concentration, not a potency): 37.1%
Beside the measured number, compound 3's estimate is 9.1 percentage points below it; the measured number falls inside the stated range.
By their numbers in this assay, from the lowest: compound 1; then compound 3; then compound 2.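

In this assay the methyl on the saturated chain carbon bound to an amine nitrogen and a carbonyl carbon can now be judged directly, and putting hydrogen in its place gives a number 17.3 percentage points higher from compound 1 to compound 3 (beyond the scatter) in a step that changes nothing else. In other words, the carboxymethyl form reads higher than the 1-carboxyethyl form, so this position does respond to a change of one carbon, although that conclusion rests on a single pair. Nothing measured here explains the rise.

Going by these compounds, it remains open whether a larger group at this place, such as ethyl or hydroxymethyl, would lower the number further, or whether hydrogen is simply a special case. On these data alone, it is also open whether the same swap would give a similar step on a core with a longer chain.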